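Guanidine on a Fused Amine: Expected Cytotoxicity of Compound 4

The source may hold more compounds than are shown below. What is called first, only, known or untested is meant among the compounds shown, and "the series" means these compounds.

Compound 1 `C1C[C@H]2[C@H]3[C@H]4[C@@H]1[C@@H]1[C@H]2[C@@H]2[C@H]3[C@@H]3CNC[C@@H]3[C@H]4[C@H]12`: 4000 nM
Compound 2 `N=C(N)N1C[C@@H]2[C@H](C1)[C@@H]1[C@@H]3[C@H]4CC[C@H]5[C@@H]3[C@H]2[C@H]2[C@@H]5[C@@H]4[C@@H]12`: 7000 nM
Compound 3 `C1C2[C@@H]3[C@H]2[C@@H]2C1[C@H]3[C@@H]1CNC[C@@H]12`: > 100000 nM

In an ADME assay on MDCK cells (Canis lupus familiaris) for cytotoxicity, with a stated time of 72 h (on this read-out lower numbers stand for higher toxicity in this test and higher numbers for lower toxicity in this test), compound 1 gives 4000 nM and compound 2 gives 7000 nM. Compound 3 reaches no number but only a limit, > 100000 nM, namely (the limit of > 100000 nM in this assay, at which 1 of the 3 values shown sits).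

Compound 2 arises from compound 1 by a group of 3 heavy atoms (1 carbon, 2 nitrogen; no ring) in place of a hydrogen atom, on an amine nitrogen in a ring; this step gave a 1.8-fold higher number from compound 1 to compound 2 (0.24 log units; within the scatter). Compound 4 `N=C(N)N1C[C@@H]2[C@H](C1)[C@H]1C3CC4[C@H]([C@H]41)[C@@H]32` has not yet been measured in this assay. It arises from compound 3 by a group of 3 heavy atoms (1 carbon, 2 nitrogen; no ring) in place of a hydrogen atom, on an amine nitrogen in a ring. The place differs in its surroundings: in compound 1 the ring is part of a fused or bridged system of six rings, in compound 3 of five rings, so this is the same kind of change, not the same change. How the core of compound 1 and the core of compound 3 differ is not broken down here.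

For compound 4 a step that the limit leaves unreadable from compound 3 to compound 4 is expected, resting on compound 1 to compound 2 giving a 1.8-fold higher number from compound 1 to compound 2 (0.24 log units; within the scatter). Since compound 3 already sits at a limit, > 100000 nM, compound 4 is expected to do so too. The estimate for compound 4 is 150000 nM, between 60000 nM and 400000 nM.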

Compound 4, minimum cytotoxic concentration: > 100000 nM
Compound 4: no number, only a limit; the forecaster's own chance of this, stated with the estimate: 80%; the middle value is on the limit's open side.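

The step from compound 3 to compound 4 cannot be read, because in this assay each of these two compounds gives only a limit, not a number: the limit of > 100000 nM in this assay, at which 2 of the 4 values shown sit.

The compounds shown leave open whether the added group changes the minimum cytotoxic concentration on the core of compound 3 at all, and in which direction.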